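The source may hold more compounds than are shown below. What is called first, only, known or untested is meant among the compounds shown, and "the series" means these compounds.

Measured compounds:
compound 1 `O=C(CC(c1ccccc1)c1c[nH]c2ccccc12)c1c(O)c2ccccc2oc1=O` — 12.4 ug/mL
compound 2 `O=C(CC(c1c(Cl)cccc1Cl)c1c[nH]c2ccccc12)c1c(O)c2ccccc2oc1=O` — 13.5 ug/mL

In a physicochemical assay, read by spectrophotometry, with a stated time of 30 min (on this read-out higher numbers stand for weaker inhibition and lower numbers for stronger inhibition), compound 1 gives 12.4 ug/mL, and compound 2 gives 13.5 ug/mL. The two numbers cannot be told apart on this assay, since a 1.1-fold higher number from compound 1 to compound 2 (0.04 log units; within the scatter). Compound 1 therefore stands together with compound 2, with nothing separating them beyond the scatter.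

Compound 3 `COc1ccc(C(CC(=O)c2c(O)c3ccccc3oc2=O)c2c[nH]c3ccccc23)cc1OC` has not yet been measured. It differs from compound 1 in one place: 3,4-dimethoxyphenyl in place of phenyl on a saturated chain carbon bound to an aromatic carbon and a saturated chain carbon. Among the measured compounds shown here, the only measured step that bears on this change is the one from compound 1 to compound 2, where a different aryl group was put on the same saturated chain carbon, and that step was a 1.1-fold higher number from compound 1 to compound 2 (0.04 log units; within the scatter). For the measured compounds named here, nothing among the measured compounds shows the two methoxy groups themselves. On this basis compound 3 is expected to sit close to compound 1, with a 1.0-fold higher number from compound 1 to compound 3 (0.00 log units; within the scatter) as the expected step and no movement beyond the scatter. The estimate for compound 3 in this assay is 12.5 ug/mL, with a range from 6 ug/mL to 26 ug/mL.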

Compound 3, half-maximal inhibitory concentration: 63.2 ug/mL
Compound 3: the middle estimate sits 5.1-fold (0.70 log units) below what was measured, and the stated range ends below it.
By their numbers in this assay, from the lowest: compounds 1 and 2 (each within the scatter of the next); then compound 3.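

In this assay, the aryl group on the saturated chain carbon bound to an aromatic carbon and a saturated chain carbon does affect the read-out: 3,4-dimethoxyphenyl in place of phenyl gives a 5.1-fold higher number from compound 1 to compound 3 (0.71 log units; beyond the scatter), and in place of 2,6-dichlorophenyl it gives a 4.7-fold higher number from compound 2 to compound 3 (0.67 log units; beyond the scatter). The earlier pair showed no separation between phenyl and 2,6-dichlorophenyl, whereas compound 3 shows that this position is not indifferent to every aryl group, with the change here running towards weaker inhibition. No evidence is available that bears on why this substitution moves the number.

The compounds shown leave open whether the shift needs both methoxy groups or would already appear with a phenyl carrying a single methoxy group. They also do not show how a hydroxyl group or an amine on that phenyl would read in this assay.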